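The compounds below may be only part of what the source reports. "The series", "measured", "known", "first", "only" and "open" are said of these compounds alone.

Compound 1 `COc1ccc(SCc2ccc(C(=O)Nc3ccccc3N)cc2)cc1`: 73.3%
Compound 2 `COc1ccc(SCc2ccc(C(=O)Nc3ccccc3N)cc2)cc1OC`: 33.6%
Compound 3 `COC(=O)c1ccccc1SCc1ccc(C(=O)Nc2ccccc2N)cc1`: 21.8%
Compound 4 `Cc1cc(C)cc(SCc2ccc(C(=O)Nc3ccccc3N)cc2)c1`: not yet measured

In a functional assay on HCT-116 cells (Homo sapiens) for inhibition, read by CCK-8 assay, with a stated time of 72 h, tested at 2 uM (on this read-out higher numbers stand for more inhibition of growth at the one concentration tested and lower numbers for less inhibition of growth), compound 1 stands highest of the three measured compounds. The change to compound 4 is 3,5-dimethylphenyl in place of 4-methoxyphenyl on a sulfur. Within the data shown here, the only measured one-place step, a number 39.7 percentage points lower from compound 1 to compound 2 (beyond the scatter), is large and also alters the group on the sulfur. Compound 3, with a different group there, reads 21.8%, also lower than compound 1. Among the measured compounds shown here, no measured compound carries methyl groups, so the size of the step is uncertain. A downward step beyond the scatter is expected, and the estimated change is a number 28.3 percentage points lower from compound 1 to compound 4 (beyond the scatter). Compound 4 is estimated at 45%, with an expected range of 20% to 72%.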

Compound 4, percent growth inhibition at one concentration: 3.22%
For compound 4 the middle estimate is 41.8 percentage points above the measured one, outside the stated range (below it).
By their numbers in this assay, from the lowest: compound 4; then compound 3; then compound 2; then compound 1.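

In this assay, the group on the sulfur is shown to be sensitive even when no oxygen is added: 3,5-dimethylphenyl in place of 4-methoxyphenyl gives a number 70.1 percentage points lower from compound 1 to compound 4 (beyond the scatter). The two groups match in heavy-atom count and each is one carbon-only aromatic ring, so the step comes without a change in either. Nothing on hand accounts for this step.

Still open, going by these compounds, is whether the loss follows the two methyl groups or the absent methoxy. On these data alone, how an amine or a carboxylic acid on this ring would read also remains unknown.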